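Removing the aromatic methyl from compound 1

The source may report more compounds than this note shows. Statements on the series, on what has been measured and on what is new or still open speak of the compounds shown alone.

Compound 1 `CC(=O)N1CCCC1C(=O)Nc1ccc(N2CCC(N3CCCC3C)C2)c(C)c1` was tested in an assay on CHO cells for displacement of a labelled ligand from histamine receptor H3 (Macaca mulatta) (a lower number here means a stronger inhibitor, a higher number a weaker inhibitor), where compound 1 gives 44.9 nM. Of the two numbers recorded so far, compound 1 has the higher one: its nearest neighbour is compound 2 `Cc1cc(NC(=O)C2CCOCC2)ccc1N1CCC(N2CCCC2C)C1`, which in this assay gives 17 nM, and the step of a 2.6-fold lower number from compound 1 to compound 2 (0.42 log units; beyond the scatter) comes from exchanging the group on the carbonyl carbon.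

Compound 3 `CC(=O)N1CCCC1C(=O)Nc1ccc(N2CCC(N3CCCC3C)C2)cc1` differs from compound 1 in a different place: hydrogen in place of methyl on an aromatic carbon. Nothing else in the structure moves; the acetylpyrrolidine amide and the rest of the shared core stay as they are in compound 1.

Among the measured compounds shown here, no measured step bears on this change. For the measured compounds named here, the only step on record, the one from compound 1 to compound 2, concerns the carbonyl substituent, not the aromatic ring, so it gives no direct guide to what losing the methyl does. With no evidence either way, the most reasonable expectation is a step of a 1.2-fold higher number from compound 1 to compound 3 (0.09 log units; within the scatter), that is, no change beyond the scatter. Compound 3 is therefore estimated at 55 nM, with a range from 15 nM to 200 nM to reflect how little is known here.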

Compound 3, inhibition constant: 14.1 nM
For compound 3 the middle estimate is 3.9-fold (0.59 log units) above the measured one; the whole stated range lies above it.
By their numbers in this assay, from the lowest: compounds 3 and 2 (each within the scatter of the next); then compound 1.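

Replacing the methyl with hydrogen on the aromatic carbon gives a 3.2-fold lower number from compound 1 to compound 3 (0.50 log units; beyond the scatter) in this assay, so the methyl is not needed for binding in this series, and the number improves without it. Among the compounds shown here, this is the first measured sign that this place on the six-membered aromatic ring affects the result, since the only earlier step concerned the other end of the molecule, at the carbonyl carbon. Only one heavy atom leaves, with no ring, hydrogen-bond donor, hydrogen-bond acceptor or charge involved, yet the change is beyond the scatter, and nothing measured here explains why it lowers the number.

The compounds shown leave open whether the number at this place follows from the size of the group, as an ethyl, a chlorine or a methoxy group on the same aromatic carbon could help to reveal. They also leave open whether hydrogen at this place has the same effect when the acetylpyrrolidine amide is replaced by the oxan-4-yl amide, so it cannot yet be said that the two changes add up.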